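The compounds below may be only part of what the source reports. "The series", "measured", "known", "first", "only" and "open" are said of these compounds alone.

Measured compounds:
compound 1 `FC(F)(F)c1ccc(NCc2cn(-c3ccccc3)nc2-c2ccc(Br)cc2)cc1`: 28000 nM
compound 2 `FC(F)(F)c1ccc(-c2nn(-c3ccccc3)cc2CNc2ccc(Br)cc2)cc1`: 17000 nM
compound 3 `Cc1ccc(-c2nn(-c3ccccc3)cc2CNc2ccc(C(F)(F)F)cc2)cc1`: 45000 nM

In an ADME assay on Vero 76 cells (Chlorocebus sabaeus) for cytotoxicity, read by MTT assay, with a stated time of 96 h (a higher number here means that more compound is tolerated, a lower number that less compound is tolerated), compound 1 gives 28000 nM and stands second highest of the three numbers. Among the measured compounds shown here, its nearest neighbour is compound 3, and the only single-point step among the measured compounds, a 1.6-fold higher number from compound 1 to compound 3 (0.21 log units; within the scatter), lies within the scatter. Compound 2 differs from compound 1 in more than one place, and its value sits a comparable distance below compound 1, again within the scatter. On the numbers shown, all three measured compounds are tolerated to a similar degree in this assay.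

Compound 4 `Cc1ccc(NCc2cn(-c3ccccc3)nc2-c2ccc(Br)cc2)cc1` has not yet been measured in this assay. It differs from compound 1 by methyl in place of trifluoromethyl on an aromatic carbon. For the measured compounds named here, no measured step changes a trifluoromethyl group, so nothing bears directly on this change; the one step that is available, from compound 1 to compound 3, swaps a ring substituent on the other aryl ring and stays within the scatter. Given that the series so far is flat in this assay, the expected step of a 1.2-fold higher number from compound 1 to compound 4 (0.07 log units; within the scatter) is one of no change beyond the scatter, in either direction. Compound 4 is therefore estimated at 33000 nM, with a range from 14000 nM to 80000 nM.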

Compound 4, half-maximal cytotoxic concentration: > 100000 nM
Compound 4: a limit, no number; the forecaster's own chance of this, stated with the estimate: 10%; middle value at least 3.0-fold (0.48 log units) from the limit.
By their numbers in this assay, from the lowest: compounds 2, 1 and 3 (each within the scatter of the next, the first and the last beyond it). At a limit, above all of these: compound 4.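

In this assay, the change from 4-(trifluoromethyl)phenyl to 4-methylphenyl gives an at least 3.5-fold higher number from compound 1 to compound 4 (0.55 log units; beyond the scatter), the only single-place step shown that lies beyond the scatter. The other single-place step, a 1.6-fold higher number from compound 1 to compound 3 (0.21 log units; within the scatter), places methyl on an aromatic carbon in place of bromo and stays within the scatter, so the flat picture from the earlier compounds does not extend to this position, and compound 4 is the only compound shown without a trifluoromethyl group. The value of compound 4, > 100000 nM, is a limit and not a number, so the step gives a lower bound on the size of the change and not the size itself: the limit of > 100000 nM in this assay, at which 1 of the 4 values shown sits.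

One pair cannot separate the loss of trifluoromethyl from the arrival of methyl, and a plain hydrogen, a chloro group, a methoxy group or an amine at this position would help to tell the two apart. Also open, as far as these compounds go, is whether methyl in place of trifluoromethyl at this position gives a step of similar size when the bromo group of compound 1 is replaced by another group, such as a nitrile or a carboxylic acid.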